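A few compounds are considered here, and "the series" means these few. Any claim that something is new, unique, unknown or untested is made for them only; others in the source may bear on it.

Measured in a functional assay on K562 cells (Homo sapiens) for cytotoxicity, read by trypan blue exclusion, with a stated time of 96 h; on this read-out higher numbers stand for weaker inhibition and lower numbers for stronger inhibition:
- compound 1 `COc1cc(OC)c(/C=C/S(=O)(=O)Cc2ccc(F)c(N)c2)c(OC)c1` gives 2500 nM
- compound 2 `COc1ccc(OC)c(/C=C/S(=O)(=O)Cc2ccc(OC)c(N)c2)c1` gives 750 nM
- compound 3 `COc1cc(OC)c(/C=C/S(=O)(=O)Cc2ccc(OC)cc2[N+](=O)[O-])c(OC)c1` gives 20000 nM

Compound 1 stands in the middle of these three, with compound 2 lower and compound 3 higher, both gaps beyond the scatter. Compound 4 `COc1cc(OC)c(/C=C/S(=O)(=O)Cc2ccc(OC)c(N)c2)c(OC)c1` is not yet measured. Methoxy in place of fluoro on an aromatic carbon, ortho to an amino group, leads from compound 1 to compound 4 (methoxy in place of fluoro on an aromatic carbon). For the measured compounds named here, no measured pair isolates this change. Compound 2 also carries 3-amino-4-methoxyphenyl and gives 750 nM, so a lower number is expected. The expected step is a 25-fold lower number from compound 1 to compound 4 (1.40 log units; beyond the scatter), toward stronger inhibition and beyond the scatter. Compound 4 is estimated at 100 nM, with an expected range of 20 nM to 600 nM.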

Compound 4, half-maximal inhibitory concentration: 2.5 nM
For compound 4 the middle estimate is 40-fold (1.60 log units) above the measured one, and the stated range ends above it.
By their numbers in this assay, from the lowest: compound 4; then compound 2; then compound 1; then compound 3.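

Methoxy in place of fluoro, ortho to an amino group, gives a 1000-fold lower number from compound 1 to compound 4 (3.00 log units; beyond the scatter) in this assay. For the compounds shown here, this is the first comparison that changes one place only, and it shows that activity here depends strongly on which of these two groups sits at this position. Nothing measured on these compounds explains a step of this size.

From the compounds shown here alone, whether hydroxy, ethoxy or chloro at this position would fall nearer compound 1 or compound 4 stays open. Also open, going by these compounds, is whether the step from fluoro to methoxy would carry over to the core of compound 2.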